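The source may report more compounds than this note shows. Statements on the series, on what has been measured and on what is new or still open speak of the compounds shown alone.

Measured compounds:
- compound 1 `COc1cccc(C(=O)Nc2cccc(-c3oc4cc(-c5ccc(F)cc5)ccc4c(=O)c3O)c2)c1`: 9950 nM
- compound 2 `COc1ccc(C(=O)Nc2cccc(-c3oc4cc(-c5ccc(F)cc5)ccc4c(=O)c3O)c2)c(F)c1`: 45300 nM

In a functional assay on HepG2 cells (Homo sapiens) for antiproliferative activity, read by CCK-8 assay, with a stated time of 72 h (a higher number here means a weaker inhibitor, a lower number a stronger inhibitor), compound 1 gives 9950 nM, the lowest of the two numbers recorded so far. Its nearest neighbour is compound 2, where the step of a 4.6-fold higher number from compound 1 to compound 2 (0.66 log units; beyond the scatter) follows from placing 2-fluoro-4-methoxyphenyl in place of 3-methoxyphenyl on a carbonyl carbon. Compound 3 `O=C(Nc1cccc(-c2oc3cc(-c4ccc(F)cc4)ccc3c(=O)c2O)c1)c1ccc(-c2ccccc2)cc1` has not yet been measured in this assay. It differs from compound 1 in one place: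

4-phenylphenyl in place of 3-methoxyphenyl on a carbonyl carbon

Among the measured compounds shown here, the group on the carbonyl carbon is again the changed part, so the step from compound 1 to compound 2 is the only measured step that bears on this change, and it was modest. That step, however, concerns a different replacement, so it gives only a rough sense of how much this position tolerates. The expectation is therefore a step of modest size or none beyond the scatter, with the direction uncertain and a weaker inhibitor somewhat more likely, which would put a 1.3-fold higher number from compound 1 to compound 3 (0.12 log units; within the scatter). Compound 3 is estimated at 13000 nM, within the range 4000 nM to 45000 nM.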

Compound 3, half-maximal inhibitory concentration: 88500 nM
For compound 3 the middle estimate is 6.8-fold (0.83 log units) below the measured one; measured number above the stated range.
By their numbers in this assay, from the lowest: compound 1; then compounds 2 and 3 (each within the scatter of the next).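

In this assay the swap of 3-methoxyphenyl for 4-phenylphenyl on the carbonyl carbon gives an 8.9-fold higher number from compound 1 to compound 3 (0.95 log units; beyond the scatter) and so provides a second replacement at this position that moves the number the same way as the first, leaving compound 1 the strongest inhibitor of the three. The two replacements differ widely in make-up, since 4-phenylphenyl brings two aromatic carbon rings and no hydrogen-bond acceptor, yet the comparison between them gives a 2.0-fold higher number from compound 2 to compound 3 (0.29 log units; within the scatter) and does not separate them in this assay. Nothing at hand accounts for these shifts at this position.

On these data alone, what stays open is whether any group on this carbonyl carbon can give a lower number than 3-methoxyphenyl does in compound 1, since the three compounds offer only substituted phenyl rings there and do not show how a ring carrying an amine or a carboxylic acid would compare. They also do not separate the contribution of the fluorine in compound 2 from that of the shifted methoxy group, and a plain phenyl or 4-methoxyphenyl group would be needed to read either one alone.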